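Cytotoxicity on KB Cells Along a Growing Ether Chain

This account rests on a few compounds, and the source may have more. Where it says the series, first, only, none or still open, it means among the compounds named here.

Within the data shown here, compound 3 `CCCOc1c(OC)c(OC)cc2c1C(=O)[C@]1(OC)C=C[C@H]2N(C(=O)OCC(C)C)N1C(=O)OCC(C)C` holds the only number among the three compounds measured in an ADME assay on KB cells (Homo sapiens) for cytotoxicity; on this read-out higher numbers stand for an effect only at larger amounts of compound and lower numbers for an effect already at smaller amounts; in it compound 3 gives 299 ug/mL. Compound 1 `COc1cc2c(c(O)c1OC)C(=O)[C@]1(OC)C=C[C@H]2N(C(=O)OCC(C)C)N1C(=O)OCC(C)C` reaches only a limit in this assay, > 300 ug/mL. Compound 2 `COc1cc2c(c(OC)c1OC)C(=O)[C@]1(OC)C=C[C@H]2N(C(=O)OCC(C)C)N1C(=O)OCC(C)C` likewise stops at a limit, > 300 ug/mL. The two measured steps that end at compound 3 are a number no higher from compound 1 to compound 3 (the limit leaves the size open) and a number no higher from compound 2 to compound 3 (the limit leaves the size open), while a step that the two limits leave unreadable from compound 1 to compound 2 remains unreadable; all three compounds sit at or just under (the limit of > 300 ug/mL in this assay, at which 2 of the 3 values shown sit).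

Compound 4 `COc1ccc(COc2c(OC)c(OC)cc3c2C(=O)[C@]2(OC)C=C[C@H]3N(C(=O)OCC(C)C)N2C(=O)OCC(C)C)cc1` differs from compound 3 in one place: 4-methoxyphenyl in place of ethyl on a saturated chain carbon bound to an oxygen on an aromatic ring. Among the measured compounds shown here, the steps that bear on this change are the two alkylations at the same aromatic oxygen, from compound 1 to compound 3 and from compound 2 to compound 3, and neither has a readable size or direction. No movement beyond the scatter can therefore be expected from them. Compound 4 is estimated to give 250 ug/mL in this assay, within 80 ug/mL to 300 ug/mL, which means an expected step of a 1.2-fold lower number from compound 3 to compound 4 (0.08 log units; within the scatter).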

Compound 4, concentration for half-maximal effect: 47.9 ug/mL
Estimate against measurement, compound 4: 5.2-fold (0.72 log units) above; measured number outside the range, below it.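

In this assay, the swap of propyl for 4-methoxybenzyl at this aromatic oxygen gives the only movement of readable size so far, a 6.2-fold lower number from compound 3 to compound 4 (0.80 log units; beyond the scatter), so this oxygen is a place where the substituent can change the number beyond the scatter. The same group also gives an at least 6.2-fold lower number from compound 2 to compound 4 (0.79 log units; beyond the scatter) and an at least 6.2-fold lower number from compound 1 to compound 4 (0.79 log units; beyond the scatter), which shows that a large aromatic ether stands apart from the hydrogen, methyl and propyl forms. These last two steps are open on one side, since compound 1 and compound 2 each stop at a limit: the limit of > 300 ug/mL in this assay, at which 2 of the 4 values shown sit.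

The compounds shown leave open whether the six-membered aromatic ring alone or its methoxy group goes with the drop, which a plain benzyl ether would separate. They also leave open whether a longer chain such as hexyl, or an amine on the ring, would move the number in the same way.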